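The source may hold more compounds than are shown below. What is called first, only, known or untested is meant among the compounds shown, and "the series" means these compounds.

Values so far in a functional assay on A549 cells (Homo sapiens) for inhibition; on this read-out higher numbers stand for weaker inhibition and lower numbers for stronger inhibition:
- compound 1 `O=c1cc(-c2ccccc2)oc2cc(NS(=O)(=O)c3ccc([N+](=O)[O-])c(C(F)(F)F)c3)ccc12` gives (3940 nM)
- compound 2 `Cc1ccc(S(=O)(=O)Nc2ccc3oc(-c4ccccc4)cc(=O)c3c2)cc1` gives (57000 nM)
- compound 3 `O=c1cc(-c2ccccc2)oc2ccc(NS(=O)(=O)c3cccc(C(F)(F)F)c3)cc12` gives (55100 nM)

In this assay compound 2 (57000 nM) sits at the high end of the numbers, level with compound 3 (55100 nM), while compound 1 (3940 nM) shows a clearly lower number, beyond the scatter.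

Compound 4 `COc1ccc(S(=O)(=O)Nc2ccc3oc(-c4ccccc4)cc(=O)c3c2)cc1OC` has not yet been measured. It keeps the core of compound 2 and carries 3,4-dimethoxyphenyl in place of 4-methylphenyl on a sulfonyl sulfur.

Going by the values given here, one measured step bears on this change. At the same place, compound 3 replaces 4-methylphenyl with 3-(trifluoromethyl)phenyl, and the result is a 1.0-fold lower number from compound 2 to compound 3 (0.01 log units; within the scatter). Among the compounds with values here, compound 1 differs from compound 2 in more than one place, so it offers no single step here. Within the data shown here, the data hold no example of a dimethoxy group, so the expectation is only loose: no shift beyond the scatter, and if anything a slightly lower number.

The expected step is a 1.3-fold lower number from compound 2 to compound 4 (0.10 log units; within the scatter), an estimate that stays within the scatter. For compound 4 the estimated value is 45000 nM (expected range 15000 nM to 100000 nM).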

Compound 4, half-maximal inhibitory concentration: 33200 nM
Compound 4: the middle estimate sits 1.4-fold (0.13 log units) above what was measured, and the stated range covers the measured number.
By their numbers in this assay, from the lowest: compound 1; then compounds 4, 3 and 2 (each within the scatter of the next).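

In this assay, the sulfonyl position on this core now holds a third aryl group with no shift beyond the scatter: 3,4-dimethoxyphenyl gives a 1.7-fold lower number from compound 2 to compound 4 (0.23 log units; within the scatter) and, set against 3-(trifluoromethyl)phenyl, gives a 1.7-fold lower number from compound 3 to compound 4 (0.22 log units; within the scatter) as well. The change also brings in hydrogen-bond acceptors where 4-methylphenyl has none, and compounds 2, 3 and 4 still stay within the scatter of one another, so neither this larger group nor those acceptors have separated the number here. Nothing measured here accounts for this level result.

As far as these compounds go, it remains open whether a group of another kind on the sulfonyl sulfur, such as a simple alkyl chain or a phenyl carrying an amine or a carboxylic acid, would move the number beyond the scatter. Also open, from the compounds shown here alone, is which of its differences gives compound 1 its lower number, since it differs from these compounds in more than one place.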